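From Free Hydroxy to Anilide: Compound 4 Awaits Testing

The source may report more compounds than this note shows. Statements on the series, on what has been measured and on what is new or still open speak of the compounds shown alone.

Compound 1 `CC(=O)SCCC(CCCCC(=O)O)SC(C)=O` reads "not active" (no number reported)
Compound 2 `O=C(CCCCC(S)CCS)Nc1ccc(Cl)cc1` reads 21.3%
Compound 3 `Cc1cccc(NC(=O)CCCCC(S)CCS)c1` reads "not active" (no number reported)

These three compounds were tested in a functional assay on HO8910 cells (Homo sapiens) for inhibition, read by MTT assay, with a stated time of 24 h, tested at 100 ug/mL (a lower number here means less inhibition of growth, a higher number more inhibition of growth at the concentration tested), and the results give the starting point only a loose footing. Compound 1 has no single number there: it is recorded as "not active" (no number reported) and its place is shared by compound 3 , recorded as "not active" (no number reported) in the same way. Only compound 2 gives a number, at 21.3% of growth inhibition.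

The next compound to be tested is compound 4 `CC(=O)SCCC(CCCCC(=O)Nc1cccc(Cl)c1)SC(C)=O`, which departs from compound 1 in one place. The change is (3-chlorophenyl)amino in place of hydroxy on a carbonyl carbon, with (3-chlorophenyl)amino in place of hydroxy on a carbonyl carbon. For the measured compounds named here, no measured step between two compounds that differ in one place is available as a guide, so the size of this step can only be judged loosely. A small rise is expected, possibly none beyond the scatter. The reasoning rests on two amides: compound 2 reached 21.3% whereas compound 3 stayed at "not active" (no number reported) in the same test. A result with no number is also quite possible. For compound 4 the expected value is 15%, with an estimated range of 0% to 35% in this assay once it is tested.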

Compound 4, percent growth inhibition at one concentration: 38.2%
Estimate against measurement, compound 4: 23.2 percentage points below, outside the stated range (above it).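

In this assay, for the compounds shown here, compound 1 gives "not active" (no number reported) and compound 4 gives 38.2%, so no step between these two compounds can be read. The compounds shown leave open how much the exchange of hydroxy for (3-chlorophenyl)amino itself changes growth inhibition. Nothing available explains the reading of compound 4.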